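This account rests on a few compounds, and the source may have more. Where it says the series, first, only, none or still open, it means among the compounds named here.

Notes on the series. Compound 1 `CCCC#Cc1cc(C)oc(=O)c1` is the chain-bearing member of the set; in a functional assay on A2780 cells (Homo sapiens) for inhibition (on this read-out higher numbers stand for weaker inhibition and lower numbers for stronger inhibition), compound 1 gives 4800 nM. Compound 2 `Cc1cc(-c2ccc(Cl)cc2)cc(=O)o1` carries chloro on an aromatic carbon; in this assay compound 2 returns only a limit of the assay, > 50000 nM. Compound 3 `COc1ccc(-c2cc(C)oc(=O)c2)cc1` carries methoxy in place of chloro on that aromatic carbon; in this assay compound 3 likewise returns only a limit, > 50000 nM. Putting methoxy in place of chloro on an aromatic carbon gives a step that the two limits leave unreadable from compound 2 to compound 3, since both ends sit at the limit of > 50000 nM in this assay, at which 2 of the 3 values shown sit. For the measured compounds named here, compound 1 therefore stands as the only compound of the three with a read number in this assay; the other two are limits and order nothing.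

Compound 4 `CCCCCC#Cc1cc(C)oc(=O)c1` is the compound still to be measured. Its difference from compound 1: ethyl in place of hydrogen on a saturated chain carbon, three bonds along the chain from a triple-bonded carbon. Going by the values given here, none of the measured steps bears on this change: the single measured step concerns a ring substituent and is unreadable, and no chain extension has been measured. In this assay the expected step is therefore a 1.2-fold lower number from compound 1 to compound 4 (0.08 log units; within the scatter), with no direction beyond the scatter. Compound 4 is expected to give 4000 nM in this assay, with a range from 1200 nM to 14000 nM.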

Compound 4, half-maximal inhibitory concentration: 2900 nM
The estimate for compound 4 lay 1.4-fold (0.14 log units) above the measured number; the range from low to high includes it.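

In this assay, for the compounds shown here, the one step that can be read is a 1.7-fold lower number from compound 1 to compound 4 (0.22 log units; within the scatter), for ethyl in place of hydrogen on a saturated chain carbon, three bonds along the chain from a triple-bonded carbon. Going by these compounds alone, the earlier compounds held a single read number and no change on the chain, so this pair is the first to show that the position accepts the propyl-to-pentyl extension with the number still readable and no shift beyond the scatter. Nothing at hand gives a cause for this step, and the one available observation concerns only the assay limit.

From the compounds shown here alone, compound 2 and compound 3 remain limits of the assay, so the step between them cannot be read and says nothing about the chain: the limit of > 50000 nM in this assay, at which 2 of the 4 values shown sit. Whether a longer chain, or a chain carrying an amine or a carboxylic acid, would move the number beyond the scatter stays open, and a single pair within the scatter sets no trend with chain length.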